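Ring contraction on the amide carbonyl: cytotoxicity outlook

The source may report more compounds than this note shows. Statements on the series, on what has been measured and on what is new or still open speak of the compounds shown alone.

Compound 1 `CC(C)N(C(=O)[C@H]1CC[C@@H]2C[C@@H]2CC1)c1cc(C#CC(C)(C)C)sc1C(=O)O` gives in an ADME assay on MT4 cells (Homo sapiens) for cytotoxicity, with a stated time of 5 days (on this read-out lower numbers stand for higher toxicity in this test and higher numbers for lower toxicity in this test), only a limit of the assay, > 20000 nM. Compound 2 `CC(C)(C)C#Cc1cc(N(C(=O)[C@H]2CC[C@H](C)CC2)[C@H]2CC[C@H](Oc3cccnc3)CC2)c(C(=O)O)s1` likewise sits at a limit in this assay with > 20000 nM. Both results rest at the limit of > 20000 nM in this assay, at which 2 of the 2 values shown sit, so compound 1 stands exactly where every number shown stands, and no step between measured compounds can be drawn. Compound 3 `CC(C)N(C(=O)[C@H]1[C@@H]2CCCC[C@@H]21)c1cc(C#CC(C)(C)C)sc1C(=O)O` differs from compound 1 by a group of 7 heavy atoms (7 carbon; one three-membered non-aromatic ring of carbon only, one six-membered non-aromatic ring of carbon only) in place of a group of 8 heavy atoms (8 carbon; one three-membered non-aromatic ring of carbon only, one seven-membered non-aromatic ring of carbon only), on a carbonyl carbon. Going by the values given here, no measured step covers this change. The step of a number no higher from compound 1 to compound 3 (the limit leaves the size open) is expected to be none beyond the scatter. Compound 3 is therefore expected at 20000 nM, within 10000 nM to 40000 nM, most probably reported again as a limit.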

Compound 3, half-maximal cytotoxic concentration: > 20000 nM
Compound 3 was reported as a limit; the forecaster's own chance of this, stated with the estimate: 85%; the middle value sits exactly at the limit.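

In this assay no step can be read from compound 1 to compound 3, as both results are limits: the limit of > 20000 nM in this assay, at which 3 of the 3 values shown sit. The compounds shown leave open where the true cytotoxic concentrations lie and whether the change on the carbonyl carbon shifts them.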